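A Carbamate in Place of the Oxolane Amide

The source may report more compounds than this note shows. Statements on the series, on what has been measured and on what is new or still open speak of the compounds shown alone.

In an assay on CHO-K1 cells for displacement of a labelled ligand from prostaglandin E2 receptor EP1 subtype (Homo sapiens) (on this read-out higher numbers stand for weaker inhibition and lower numbers for stronger inhibition), compound 3 `Cc1cc(NC(=O)C2CCOC2)nn1Cc1cc(Cl)ccc1OCc1ccccc1` gives 39.8 nM, the lowest of the three numbers measured. Compound 1 `Cc1cc(C(N)=O)nn1Cc1cc(Cl)ccc1OCc1ccccc1` gives 126 nM and compound 2 `Cc1cc(C(=O)NC(C)C)nn1Cc1cc(Cl)ccc1OCc1ccccc1` gives 126 nM; the step of no change at the digits printed from compound 1 to compound 2 (within the scatter) stays within the scatter, while a 3.2-fold lower number from compound 1 to compound 3 (0.50 log units; beyond the scatter) and a 3.2-fold lower number from compound 2 to compound 3 (0.50 log units; beyond the scatter) both favour compound 3. Compound 4 `Cc1cc(NC(=O)OC(C)(C)C)nn1Cc1cc(Cl)ccc1OCc1ccccc1` differs from compound 3 by tert-butoxy in place of oxolan-3-yl on a carbonyl carbon. Within the data shown here, no measured step changes the group on this carbonyl carbon alone; the two steps into compound 3 exchange the whole carbamoyl-type group, so they bear on this change only loosely. The step of a 1.3-fold higher number from compound 3 to compound 4 (0.10 log units; within the scatter) is therefore expected to stay within the scatter. Compound 4 is estimated at 50 nM, within 20 nM to 125 nM.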

Compound 4, half-maximal inhibitory concentration: 25.1 nM
Beside the measured number, compound 4's estimate is 2.0-fold (0.30 log units) above it; the range from low to high includes it.
By their numbers in this assay, from the lowest: compounds 4 and 3 (each within the scatter of the next); then compounds 1 and 2 (each within the scatter of the next).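

On a carbonyl carbon whose other neighbour is an amide-type nitrogen, the ring of oxolan-3-yl gives way to the open tert-butoxy, with the same heavy-atom count, and a 1.6-fold lower number from compound 3 to compound 4 (0.20 log units; within the scatter) stays within the scatter in this assay. The advantage over the carbamoyl-type compounds therefore does not depend on the oxolane ring, as a 5.0-fold lower number from compound 2 to compound 4 (0.70 log units; beyond the scatter) and a 5.0-fold lower number from compound 1 to compound 4 (0.70 log units; beyond the scatter) both lie beyond the scatter. Nothing available explains these steps. From the compounds shown here alone, whether a dimethylamino group or a longer chain such as n-butyl on this carbonyl carbon would hold the number remains open.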